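A Tertiary Alcohol in Place of the Nitrile Terminus

This account rests on a few compounds, and the source may have more. Where it says the series, first, only, none or still open, it means among the compounds named here.

Of the compounds shown here, three with a shared core have been measured in an assay on isolated protein for binding affinity to leukotriene B4 receptor 1 (Homo sapiens), tested at 1 uM; on this read-out higher numbers stand for more inhibition at the one concentration tested (going by the name of the read-out) and lower numbers for less inhibition. Compound 1 `CCc1cc(C(C)=O)c(O)cc1OCCCCC#N` gives 57%. Compound 3 `CCc1cc(C(C)=O)c(O)cc1OCCCC(C)(C)C#N` gives 46%, and the one-place change from compound 1 to compound 3, 1-cyano-1-methylethyl in place of cyanomethyl on a saturated chain carbon, reads a number 11 percentage points lower from compound 1 to compound 3 (beyond the scatter). Compound 2 `C=CCc1cc(C(C)=O)c(O)cc1OCCCCCC#N` gives 41%; against compound 1 it stands beyond the scatter, against compound 3 within it, so on the numbers compound 2 is not separated from compound 3 and sits below compound 1.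

Compound 4 `C=CCc1cc(C(C)=O)c(O)cc1OCCCCCC(C)(C)O` has not yet been measured in this assay. It differs from compound 2 in one place: 1-hydroxy-1-methylethyl in place of cyano on a saturated chain carbon, five bonds along the chain from an oxygen on an aromatic ring. Within the data shown here, of the measured steps, only the step from compound 1 to compound 3 bears on it, since that step likewise exchanges an unbranched chain terminus for a branched one, and it was modest. Among the measured compounds shown here, no measured pair shows a nitrile exchanged for a hydroxyl, so that part of the change rests on no data. A small downward step or none beyond the scatter is therefore expected, a number 5 percentage points lower from compound 2 to compound 4 (within the scatter). Compound 4 is estimated at 36%, within a range from 16% to 56%.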

Compound 4, a percentage reported as inhibition, at one concentration (the size of the read-out at that concentration, not a potency): 60%
For compound 4 the middle estimate is 24 percentage points below the measured one, outside the stated range (above it).
By their numbers in this assay, from the lowest: compounds 2 and 3 (each within the scatter of the next); then compounds 1 and 4 (each within the scatter of the next).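

In this assay, putting 1-hydroxy-1-methylethyl in place of cyano, on a saturated chain carbon five bonds along the chain from an oxygen on an aromatic ring, gives a number 19 percentage points higher from compound 2 to compound 4 (beyond the scatter), the first upward step among the compounds shown. Among these compounds, the only earlier step, a number 11 percentage points lower from compound 1 to compound 3 (beyond the scatter), also ended in a branched terminus but kept the nitrile and went down, so a branched chain end does not by itself set the direction across these two pairs, and the new step also replaces a group with no hydrogen-bond donor by one with a single donor. Nothing in the available data accounts for the size or direction of this step.

The single exchange changes the group's size and its terminal atoms together, so the compounds shown cannot separate the hydroxyl from the two methyl groups around it; a primary alcohol, a methyl ether or a tertiary amine at the same chain end would bear on that. As far as these compounds go, whether the exchange reads the same way on a shorter chain also remains open.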